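The compounds below may be only part of what the source reports. "The series", "measured", "known", "first", "only" and "open" are said of these compounds alone.

Of the compounds shown here, three have numbers so far in a functional assay on MCF7 cells (Homo sapiens) for inhibition, read by sulforhodamine B assay, with a stated time of 48 h; a lower number here means a stronger inhibitor of growth, a higher number a weaker inhibitor of growth. Compound 1 (`c1cc(OC2CCCCC2)ccc1NC1=NCCO1`) gives 19100 nM there. Compound 2 (`O=C(CCl)NC(=O)Nc1ccc(C2CCCCC2)cc1`) gives 1500 nM there. Compound 3 (`O=C(CCl)NC(=O)Nc1ccc(OC2CCCC2)cc1`) gives 3900 nM, the middle number of the three, above compound 2 and below compound 1.

Next comes compound 4 (`O=C(CCl)NC(=O)Nc1ccc(OC2CCCCC2)cc1`), which differs from compound 3 as follows: cyclohexyl in place of cyclopentyl on an oxygen on an aromatic ring. In words, this is cyclohexyl in place of cyclopentyl on an oxygen on an aromatic ring, or cyclopentyloxy to cyclohexyloxy.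

Going by the values given here, one measured step bears on this change: a 2.6-fold higher number from compound 2 to compound 3 (0.41 log units; beyond the scatter), which is modest and puts cyclopentyloxy in place of cyclohexyl on an aromatic carbon. That step alters the ring and the oxygen together, so it covers the present change only in part. Compound 4 keeps the oxygen of compound 3 and carries the cyclohexyl of compound 2. Among the compounds with values here, no measured step links compound 1 to compound 4, so compound 1 is not used here.

Given the modest size of a 2.6-fold higher number from compound 2 to compound 3 (0.41 log units; beyond the scatter), a smaller move towards a lower number is expected in this assay, probably within the scatter. The expected step is a 1.6-fold lower number from compound 3 to compound 4 (0.19 log units; within the scatter). For compound 4 the estimated value is 2500 nM, with an expected range from 1200 nM to 5500 nM.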

Compound 4, concentration for 50% growth inhibition: 4700 nM
Estimate against measurement, compound 4: 1.9-fold (0.27 log units) below, and the stated range covers the measured number.
By their numbers in this assay, from the lowest: compound 2; then compounds 3 and 4 (each within the scatter of the next); then compound 1.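

In this assay the ring on the oxygen can now be read on its own: there is a 1.2-fold higher number from compound 3 to compound 4 (0.08 log units; within the scatter) with cyclohexyl in place of cyclopentyl, so this change of ring size does not separate the two compounds at this position. With the cyclohexyl held constant, the oxygen can also be read alone, and there is a 3.1-fold higher number from compound 2 to compound 4 (0.50 log units; beyond the scatter) when cyclohexyloxy replaces cyclohexyl on the aromatic carbon, while the group on the nitrogen on the aromatic ring also matters with cyclohexyloxy held constant, as there is a 4.1-fold lower number from compound 1 to compound 4 (0.61 log units; beyond the scatter) when the open-chain group of 7 heavy atoms replaces the group with the five-membered non-aromatic ring. No evidence on the origin of these steps is available for this series.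

The compounds shown leave open whether an open chain such as butoxy, or a ring carrying an amine such as piperidinyloxy, would stay level with cyclopentyloxy and cyclohexyloxy on the aromatic ring. They also leave open how much of the result rests on the chlorine of the open-chain group, which a comparison with a bromine or a hydrogen in its place would address.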